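Removing the 4-methylphenyl group from the aryl amine of compound 1

This account rests on a few compounds, and the source may have more. Where it says the series, first, only, none or still open, it means among the compounds named here.

Compound 1 `Cc1ccc(Nc2nccc(-c3ccnc4ccccc34)n2)cc1` has the higher number of the two measured compounds in a functional assay on PC-3 cells (Homo sapiens) for cytotoxicity, read by sulforhodamine B assay, with a stated time of 48 h, tested at 50 uM (a higher number here means more inhibition at the concentration tested (going by the name of the read-out), a lower number less inhibition), where compound 1 gives 100%. Compound 2 `FC(F)(F)c1ccc(Nc2nccc(-c3cnc4ccccc4c3)n2)cc1` differs from compound 1 in several places; in this assay compound 2 gives 22.9%, a number far lower than that of compound 1 and beyond the scatter. Among the measured compounds shown here, no pair of measured compounds differs in only one place, so no measured step is available to guide the next change directly.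

Compound 3 `Nc1nccc(-c2ccnc3ccccc23)n1` is the compound not yet measured. It departs from compound 1 by hydrogen in place of 4-methylphenyl on a nitrogen on an aromatic ring; cut one bond further out, the change reads (4-methylphenyl)amino to amino. The 4-methylphenyl group that leaves is a large part of compound 1, and compound 1 has the highest number seen here, 100%. For the measured compounds named here, since no measured compound lacks this group, any expectation rests on the size of the change alone. A large step downward is expected, a number 70 percentage points lower from compound 1 to compound 3 (beyond the scatter), well beyond the scatter. Compound 3 is therefore estimated at 30% in this assay, with a range from 5% to 70%.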

Compound 3, a percentage reported as inhibition, at one concentration (the size of the read-out at that concentration, not a potency): 77.4%
Estimate against measurement, compound 3: 47.4 percentage points below; measured number outside the range, above it.
By their numbers in this assay, from the lowest: compound 2; then compound 3; then compound 1.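

In this assay, among the compounds shown here, the change to hydrogen on a nitrogen on an aromatic ring gives a number 22.6 percentage points lower from compound 1 to compound 3 (beyond the scatter), the first measured step at a single place. The 4-methylphenyl group therefore contributes to the read-out at this one concentration, but it is not required for it: without this group and its seven carbon atoms, compound 3 still gives 77.4%, so the amino compound keeps a clear inhibition reading. Nothing measured here accounts for the size of this step, and these single-concentration readings give no potency.

The compounds shown leave open what a group of intermediate size on the same nitrogen would give, such as a methyl or a cyclopropyl group, and whether an acetyl group or a phenyl ring carrying a carboxylic acid would fall closer to compound 1 or to compound 3. They also leave open whether the same exchange of (4-methylphenyl)amino to amino would give a step of similar size on any other core.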